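Fluorophenyl Position Across Two Hydroxyphenyl Patterns

A few compounds are considered here, and "the series" means these few. Any claim that something is new, unique, unknown or untested is made for them only; others in the source may bear on it.

Compound 1 `Oc1ccc(-c2cc(-c3cccc(F)c3)cc(-c3ccccc3O)n2)cc1` was tested in a functional assay on HCT-15 cells (Homo sapiens) for inhibition; a higher number here means a weaker inhibitor, a lower number a stronger inhibitor. In this assay compound 1 gives only a limit of the assay, > 50000 nM. Compound 2 `Oc1ccc(-c2cc(-c3ccc(F)cc3)cc(-c3ccccc3O)n2)cc1` carries 4-fluorophenyl in place of 3-fluorophenyl on an aromatic carbon. In this assay compound 2 also gives only a limit of the assay, > 50000 nM. The step between them is a step that the two limits leave unreadable from compound 1 to compound 2, and it cannot be read owing to the limit of > 50000 nM in this assay, at which 2 of the 3 values shown sit.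

Compound 3 `Oc1cccc(-c2cc(-c3cccc(F)c3)cc(-c3cccc(O)c3)n2)c1` rests on a different core; the difference between the two cores is not broken down here. In this assay, going by the values given here, compound 3 gives 7860 nM, the only number among the three measured compounds.

Compound 4 `Oc1cccc(-c2cc(-c3ccc(F)cc3)cc(-c3cccc(O)c3)n2)c1` carries 4-fluorophenyl in place of 3-fluorophenyl on an aromatic carbon. Among the compounds with values here, this is the same kind of change as the one from compound 1 to compound 2, but the surroundings of the place differ: in compound 1 the carbon is meta to a 2-hydroxyphenyl group and meta to a 4-hydroxyphenyl group, while in compound 3 it is meta to two 3-hydroxyphenyl groups. The earlier step has no readable size, so the measured data give no size for this kind of change. The step expected from compound 3 to compound 4 is a 1.0-fold higher number from compound 3 to compound 4 (0.01 log units; within the scatter), a step taken to sit within the usual scatter. Compound 4 is therefore expected to give 8000 nM in this assay, with a range from 3000 nM to 30000 nM.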

Compound 4, half-maximal inhibitory concentration: 6310 nM
The estimate for compound 4 lay 1.3-fold (0.10 log units) above the measured number; measured number inside the range.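

In this assay, replacing 3-fluorophenyl with 4-fluorophenyl, on the aromatic carbon opposite the ring nitrogen and meta to two 3-hydroxyphenyl groups, gives a 1.2-fold lower number from compound 3 to compound 4 (0.10 log units; within the scatter), so on this core the two fluorophenyl groups cannot be told apart. The same replacement on the core of compound 1 cannot be read, because compound 1 and compound 2 both give only a limit of the assay and not a number: the limit of > 50000 nM in this assay, at which 2 of the 4 values shown sit. Going by these compounds alone, the result therefore shows that the change is silent on one core, but it does not show that the change carries over from one core to the other, since there is only one readable step and nothing to set beside it.

The compounds shown leave open how the placing of the hydroxyl groups on the two hydroxyphenyl rings bears on the read-out, as the two cores differ in more than one place and no single hydroxyl shift is isolated here. Also open is what an amine, a carboxylic acid or a longer chain would do in place of the fluorine on this phenyl ring, as every compound shown carries a fluorine there.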